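The compounds below may be only part of what the source reports. "The series", "measured", "known", "first", "only" and "open" are said of these compounds alone.

Measured so far in a functional assay on A549 cells (Homo sapiens) for inhibition, read by MTT assay, with a stated time of 48 h; a lower number here means a stronger inhibitor, a higher number a weaker inhibitor:
compound 1 `COc1ccc2c(=O)c(/C=C/C(=O)NCc3cccc(F)c3)coc2c1` gives 26900 nM
compound 2 `Cc1ccccc1NC(=O)/C=C/c1coc2cc(O)ccc2c1=O` gives only a limit of the assay, > 100000 nM
compound 3 `Cc1ccc(CNC(=O)/C=C/c2coc3cc(O)ccc3c2=O)cc1` gives 17400 nM

Compound 1 and compound 3 give numbers that lie within the scatter of each other, so no order between them is claimed. Compound 2 sits at the limit of > 100000 nM in this assay, at which 1 of the 3 values shown sits, and yields no number. The next compound, compound 4 `COc1ccc2c(=O)c(/C=C/C(=O)Nc3ccc(C)cc3)coc2c1`, differs from compound 1 in one place: 4-methylphenyl in place of 3-fluorobenzyl on an amide-type nitrogen. Within the data shown here, the only measured step that touches the group on the amide nitrogen is an at least 5.7-fold lower number from compound 2 to compound 3 (0.75 log units; beyond the scatter), which ran from an aryl placed directly on the nitrogen to a benzyl and lowered the number. Among the measured compounds shown here, the present change runs the other way, from a benzyl to an aryl on the nitrogen, though the entering group is 4-methylphenyl rather than 2-methylphenyl and the core carries methoxy rather than hydroxy, a combination for which no step has been measured. A higher number, toward the weak end, is therefore expected in this assay, and a limit is a real possibility. Compound 4 is estimated at 60000 nM, within 25000 nM to 150000 nM. That estimate corresponds to the expected step of a 2.2-fold higher number from compound 1 to compound 4 (0.35 log units; beyond the scatter).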

Compound 4, half-maximal inhibitory concentration: 17500 nM
Compound 4: middle estimate off by 3.4-fold (0.54 log units), on the high side; the measured number lies below the stated range.
By their numbers in this assay, from the lowest: compounds 3, 4 and 1 (each within the scatter of the next). At a limit, above all of these: compound 2.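

In this assay, replacing 3-fluorobenzyl with 4-methylphenyl on an amide-type nitrogen gives a 1.5-fold lower number from compound 1 to compound 4 (0.19 log units; within the scatter). An aryl group placed directly on this nitrogen therefore still gives a measured number here, and compound 4 goes against any general reading of an at least 5.7-fold lower number from compound 2 to compound 3 (0.75 log units; beyond the scatter) as favouring a benzyl over an aryl group. Compound 2 alone gives a limit of the assay, not a number: the limit of > 100000 nM in this assay, at which 1 of the 4 values shown sits.

The compounds shown do not separate the 2-methylphenyl group from the hydroxy on the core as the source of that limit, and no pair differs only in hydroxy versus methoxy. Also open, as far as these compounds go, is how the series responds to a longer chain between the amide nitrogen and the aromatic ring, or to an amine or carboxylic acid on that ring.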